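This account rests on a few compounds, and the source may have more. Where it says the series, first, only, none or still open, it means among the compounds named here.

Compound 2 `Cc1ccc2c(Cc3nn4c(CO)c(-c5ccc(Cl)cc5)nc4s3)coc2c1` was tested in a functional assay on the whole organism (strain Wistar albino) for inhibition, with Rattus norvegicus as the target, read by paw edema, with a stated time of 5 h, at a dose of 100 mg/kg by the oral route; on this read-out higher numbers stand for more inhibition at the one dose given (going by the name of the read-out) and lower numbers for less inhibition. For the measured compounds named here, compound 2 gives 58.9%, which stands highest of the two numbers measured so far, though within the scatter of compound 1 `Cc1ccc2c(Cc3nn4cc(-c5ccc(Cl)cc5)nc4s3)coc2c1`, which in this assay gives 58.1%. Going by the values given here, the one measured step, a number 0.8 percentage points higher from compound 1 to compound 2 (within the scatter), put hydroxymethyl in place of hydrogen on an aromatic carbon and moved the read-out by nothing beyond the scatter. Compound 3 `Cc1ccc2c(Cc3nn4c(C#N)c(-c5ccc(Cl)cc5)nc4s3)coc2c1` differs from compound 2 by cyano in place of hydroxymethyl on an aromatic carbon. Among the compounds with values here, the step from compound 2 to compound 3 touches the same aromatic carbon, where the only measured step stayed within the scatter; beyond that there is no measured guide to exchanging hydroxymethyl for cyano. A step within the scatter is therefore expected, in no particular direction, a number 0.9 percentage points lower from compound 2 to compound 3 (within the scatter). Compound 3 is estimated to give 58% in this assay, with a range from 46% to 70%.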

Compound 3, a percentage reported as inhibition, in the whole organism at one dose (the size of the read-out at that dose, not a potency): 53.5%
Estimate against measurement, compound 3: 4.5 percentage points above; measured number inside the range.
By their numbers in this assay, from the lowest: compounds 3, 1 and 2 (each within the scatter of the next).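

At this aromatic carbon a second replacement also stays within the scatter in this assay: exchanging hydroxymethyl for cyano gives a number 5.4 percentage points lower from compound 2 to compound 3 (within the scatter), and cyano in place of hydrogen gives a number 4.6 percentage points lower from compound 1 to compound 3 (within the scatter). Hydrogen, hydroxymethyl and cyano thus all fall within the scatter of one another, so the change from 1 hydrogen-bond donor in hydroxymethyl to 0 hydrogen-bond donors in cyano comes with no step beyond the scatter. No measurement is available to explain these numbers.

Going by these compounds, whether another group at this carbon, such as an amine, a carboxylic acid or a longer chain, would move the read-out beyond the scatter remains open. Also open, on these data alone, is whether these three compounds would stay this close at other doses or times, as the numbers describe one dose at one stated time.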